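Moving the Halogen Around the Benzyl Arm of Compound 3

The source may report more compounds than this note shows. Statements on the series, on what has been measured and on what is new or still open speak of the compounds shown alone.

Three measured compounds share one core and differ only in the group attached through a nitrogen on that core. Compound 1 `Cc1cc(Nc2nc(NC3CCNC3)nc3[nH]ncc23)n[nH]1` carries a pyrrolidin-3-yl group, compound 2 `Cc1cc(Nc2nc(NCc3ccccc3F)nc3[nH]ncc23)n[nH]1` a 2-fluorobenzyl group and compound 3 `Cc1cc(Nc2nc(NCc3cccc(F)c3)nc3[nH]ncc23)n[nH]1` a 3-fluorobenzyl group. In an assay on isolated protein for inhibition of serine/threonine-protein kinase PAK 4 (Homo sapiens), read by HTRF, with a stated time of 60 min (on this read-out lower numbers stand for stronger inhibition and higher numbers for weaker inhibition), compound 1 gives 1050 nM, compound 2 gives 389 nM and compound 3 gives 458 nM. Both benzyl compounds do better than the pyrrolidinyl one: a 2.7-fold lower number from compound 1 to compound 2 (0.43 log units; beyond the scatter) and a 2.3-fold lower number from compound 1 to compound 3 (0.36 log units; beyond the scatter). Between the two benzyl compounds, a 1.2-fold higher number from compound 2 to compound 3 (0.07 log units; within the scatter), so their numbers cannot be told apart. Compound 3 thus stands second highest of the three numbers, close to compound 2 and clearly apart from compound 1.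

Compound 4 `Cc1cc(Nc2nc(NCc3ccc(Cl)cc3)nc3[nH]ncc23)n[nH]1` changes the benzyl arm once more: 4-chlorophenyl in place of 3-fluorophenyl on a saturated chain carbon bound to a nitrogen on an aromatic ring. Among the compounds with values here, the one measured step that speaks to this change is a 1.2-fold higher number from compound 2 to compound 3 (0.07 log units; within the scatter), where shifting the fluorine from one ring position to another left the number within scatter. Within the data shown here, no measured step swaps fluorine for chlorine, so that part of the change is uncharted. On this basis the expected step is a 1.1-fold lower number from compound 3 to compound 4 (0.04 log units; within the scatter), which is to say nothing beyond the scatter. Compound 4 is therefore estimated at 420 nM, with a range from 150 nM to 1200 nM.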

Compound 4, half-maximal inhibitory concentration: 515 nM
Compound 4: the middle estimate sits 1.2-fold (0.09 log units) below what was measured; the range from low to high includes it.
By their numbers in this assay, from the lowest: compounds 2, 3 and 4 (each within the scatter of the next); then compound 1.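

In this assay, 4-chlorophenyl in place of 3-fluorophenyl gives a 1.1-fold higher number from compound 3 to compound 4 (0.05 log units; within the scatter) and, set against the 2-fluorophenyl arm, a 1.3-fold higher number from compound 2 to compound 4 (0.12 log units; within the scatter) so the first chlorine on this arm, in a new ring position, produces no change that can be told from scatter. The benzyl arm's separation from the pyrrolidin-3-yl group now extends to a third ring, with a 2.0-fold lower number from compound 1 to compound 4 (0.31 log units; beyond the scatter) and this step, like those to the two fluorinated compounds, lies beyond the scatter. No supporting data are available to explain why these three halogen-bearing rings give numbers that cannot be told apart.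

The halogen swap and the shift in ring position arrive together in compound 4, so a 4-fluorobenzyl or a 3-chlorobenzyl group would be needed to read each change alone. Also open, going by these compounds, is whether a ring carrying a methoxy group or a carboxylic acid, or a phenethyl arm in place of the benzyl arm, would move the number beyond the scatter.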